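Moving the Aryl Group: From Compound 3 to Compound 4

The compounds below may be only part of what the source reports. "The series", "measured", "known", "first", "only" and "open" are said of these compounds alone.

Compound 1 `COc1cc(-n2cnc3ccc(-c4ccc(C(C)=O)cc4)cc32)cc(OC)c1OC`: 1540 nM
Compound 2 `COc1cc(-n2cnc3ccc(-c4ccc([N+](=O)[O-])cc4)cc32)cc(OC)c1OC`: 740 nM
Compound 3 `COc1cc(-n2cnc3ccc(-c4cccc(O)c4)cc32)cc(OC)c1OC`: 350 nM

These values come from a functional assay on MCF7 cells (Homo sapiens) for antiproliferative activity, read by MTT assay, with a stated time of 72 h; on this read-out lower numbers stand for stronger inhibition and higher numbers for weaker inhibition. Compound 3 gives the lowest of the three numbers. Compound 4 `COc1cc(-n2cnc3ccc(-c4ccc(Cl)cc4)cc32)cc(OC)c1OC` has not yet been measured and carries 4-chlorophenyl in place of 3-hydroxyphenyl on an aromatic carbon. The closest guides are the changes to 3-hydroxyphenyl from 4-acetylphenyl, a 4.4-fold lower number from compound 1 to compound 3 (0.64 log units; beyond the scatter), and from 4-nitrophenyl, a 2.1-fold lower number from compound 2 to compound 3 (0.33 log units; beyond the scatter). For the measured compounds named here, both are modest, and no compound with chlorine has been measured, so only a modest rise is expected here. The expected change is a 2.3-fold higher number from compound 3 to compound 4 (0.36 log units; beyond the scatter). For compound 4, the estimated value is 800 nM, within an expected range of 300 nM to 2200 nM.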

Compound 4, half-maximal inhibitory concentration: 1320 nM
Compound 4: the middle estimate sits 1.7-fold (0.22 log units) below what was measured, within the range that was stated.
By their numbers in this assay, from the lowest: compound 3; then compounds 2, 4 and 1 (each within the scatter of the next, the first and the last beyond it).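

Replacing 3-hydroxyphenyl with 4-chlorophenyl gives a 3.8-fold higher number from compound 3 to compound 4 (0.58 log units; beyond the scatter), so compound 3 keeps its place as the lowest of the four. The chloro compound cannot be separated from either the nitro compound, with a 1.8-fold higher number from compound 2 to compound 4 (0.25 log units; within the scatter), or the acetyl compound, with a 1.2-fold lower number from compound 1 to compound 4 (0.07 log units; within the scatter). Nothing here explains these differences.

Compound 3 and compound 4 differ in both the group and where it sits, so the two effects cannot be separated. On these data alone, how 4-hydroxyphenyl, 3-chlorophenyl or a phenyl carrying an amine would compare remains open.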